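Removing the methanesulfonamido group from compound 1

A few compounds are considered here, and "the series" means these few. Any claim that something is new, unique, unknown or untested is made for them only; others in the source may bear on it.

Going by the values given here, compound 1 `CCCCN(c1nc2c(NS(C)(=O)=O)cccc2o1)[C@H](C)c1ccc(-c2ccccc2-c2nnn[nH]2)cc1` is one of two compounds measured in an ADME assay on the whole organism (Macaca fascicularis) for pharmacokinetics, read by LC-MS, using cassette dosing, at a dose of 1 mg/kg by the oral route; a lower number here means less compound in the circulation, a higher number more compound in the circulation at the dose given. In this assay compound 1 gives 49.9 nM, the lower of the two numbers. The other measured compound is compound 2 `CCCCN(c1nc2c(C(=O)O)cccc2o1)[C@H](C)c1ccc(-c2cc(F)ccc2-c2nc(=O)o[nH]2)cc1`, which in this assay gives 1180 nM, a number far higher than that of compound 1 and well beyond the usual scatter; these two compounds differ in several places at once, so their gap cannot be tied to any single change.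

Compound 3 `CCCCN(c1nc2ccccc2o1)[C@H](C)c1ccc(-c2ccccc2-c2nnn[nH]2)cc1` has not yet been measured in this assay. It differs from compound 1 in one place (hydrogen in place of methanesulfonamido on an aromatic carbon). Among the compounds with values here, no measured pair in this set shows the effect of such a change, so the direction of the step is open. The account expects a modest rise in the measured number from compound 1 to compound 3, of a size a 2.2-fold higher number from compound 1 to compound 3 (0.34 log units; beyond the scatter), with a real chance that it stays within the scatter. Compound 3 is therefore expected to give about 110 nM in this assay, within a range from 30 nM to 400 nM.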

Compound 3, maximal plasma concentration: 29.2 nM
Compound 3: the middle estimate sits 3.8-fold (0.58 log units) above what was measured; the whole stated range lies above it.
By their numbers in this assay, from the lowest: compounds 3 and 1 (each within the scatter of the next); then compound 2.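

Taking the methanesulfonamido group off this aromatic carbon, on the six-membered aromatic ring of carbon only, leaves hydrogen in its place, and in this assay this gives a 1.7-fold lower number from compound 1 to compound 3 (0.23 log units; within the scatter). Going by these compounds alone, this is the first reading in the set that isolates a single place, since the only earlier comparison mixed several changes at once; it shows that in this pair, the whole methanesulfonamido group can go without a change in the maximal plasma concentration that stands clear of the usual scatter. No measurement is available here that would account for this result.

Going by these compounds, whether another group on the same aromatic carbon, such as an amine or a methoxy group, would give a number beyond the scatter of compound 3 remains open, and a single pair cannot show whether the same holds on other versions of the core. Also open, on these data alone, is which of the several places in which compound 2 differs from the other two goes with the much higher number of compound 2, 1180 nM, in this assay.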